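Sugar-triazole series: solubility outlook for compound 4

The source may report more compounds than this note shows. Statements on the series, on what has been measured and on what is new or still open speak of the compounds shown alone.

Measured so far in a physicochemical assay for solubility, read by LC-MS, using the shake flask method, measured as thermodynamic solubility, with a stated time of 24 h, at pH 6.5; on this read-out higher numbers stand for higher solubility and lower numbers for lower solubility:
- compound 1 `O=C(O)c1cccc(-n2cc(CO[C@H]3O[C@H](CO)[C@@H](O)[C@H](O)[C@@H]3O)nn2)c1`: > 3000 ug/mL
- compound 2 `Nc1ccc(-n2cc(CO[C@H]3O[C@H](CO)[C@@H](O)[C@H](O)[C@@H]3O)nn2)cc1`: > 2000 ug/mL
- compound 3 `O=[N+]([O-])c1ccc(-n2cc(CO[C@H]3O[C@H](CO)[C@@H](O)[C@H](O)[C@@H]3O)nn2)cc1`: 2600 ug/mL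

The value of compound 1 is a limit of this assay, not a number. The value of compound 2 is likewise a limit. Going by the values given here, compound 3 gives the only number in this assay; the other two values stand at limits, the limit of > 2000 ug/mL in this assay, at which 1 of the 3 values shown sits, and (the limit of > 3000 ug/mL in this assay, at which 1 of the 3 values shown sits).

Of the measured steps, an at least 1.1-fold lower number from compound 1 to compound 3 (0.06 log units; that floor lies within the scatter) carries a floor that lies within the scatter, and a step that the limit leaves unreadable from compound 2 to compound 3 cannot be read at all. Neither step therefore sets a direction or size that can be carried over.

Compound 4 `COc1ccc(-n2cc(CO[C@H]3O[C@H](CO)[C@@H](O)[C@H](O)[C@@H]3O)nn2)cc1` is unmeasured. Its difference from compound 3 is methoxy in place of nitro on an aromatic carbon. Among the compounds with values here, the only readable step into compound 3 shows no change beyond the scatter, and the nitro-to-amino step is unreadable, so no step beyond the scatter is expected from this change either.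

For compound 4 in this assay a value near that of compound 3 is expected, namely 2500 ug/mL, with a range of 1200 ug/mL to 3500 ug/mL. The step that this estimate implies, a 1.0-fold lower number from compound 3 to compound 4 (0.02 log units; within the scatter), is expected to stay within the scatter.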

Compound 4, solubility: 2600 ug/mL
The estimate for compound 4 lay 1.0-fold (0.02 log units) below the measured number; the measured number falls inside the stated range.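

In this assay, the change from 4-nitrophenyl to 4-methoxyphenyl gives no change at the digits printed from compound 3 to compound 4 (within the scatter), so this place on the aromatic ring, para to a large group, now has a direct comparison between two numbers rather than one number set against limits. With nitro leaving (3 heavy atoms) and methoxy entering (2 heavy atoms), the exchange leaves this assay without a step beyond the scatter for this pair, though that holds for this one pair only. The other readable step, an at least 1.1-fold lower number from compound 1 to compound 4 (0.06 log units; that floor lies within the scatter), gives only a floor and sets no direction, and the step involving the 4-aminophenyl compound cannot be read because compound 2 stands at a limit of the assay: the limit of > 2000 ug/mL in this assay, at which 1 of the 4 values shown sits.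

From the compounds shown here alone, whether a chlorine atom, a trifluoromethyl group or a longer chain such as butoxy at this place would move the read-out beyond the scatter stays open. Also open is how far compound 1 lies from the other compounds, its value being a limit of the assay: the limit of > 3000 ug/mL in this assay, at which 1 of the 4 values shown sits.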